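A few compounds are considered here, and "the series" means these few. Any claim that something is new, unique, unknown or untested is made for them only; others in the source may bear on it.

Measured so far in a physicochemical assay for lipophilicity, at pH 7.4 (a higher number here means a more lipophilic compound, a lower number a more polar compound), of these compounds
- compound 1 `CCOc1ccc2c(c1)C=CN(C)C(=O)C2C` gives 5
- compound 2 `COCCOc1ccc2c(c1)C=CN(C)C(=O)[C@@H]2C` gives 4

Going by the values given here, of these two numbers, the one for compound 1 is the highest, and compound 2 lies lower by a gap beyond the usual scatter. Still unmeasured is compound 3 `CC1C(=O)N(C)C=Cc2cc(OCC(C)(C)O)ccc21`, which differs from compound 1 by 1-hydroxy-1-methylethyl in place of methyl on a saturated chain carbon bound to an oxygen on an aromatic ring and nothing else. Among the compounds with values here, no measured step isolates one such change. Within the data shown here, the side chain of compound 1 also differs in compound 2, which gives 4 as the only guide, so a downward step of similar size is expected. The estimate is a number 1.10 log units lower from compound 1 to compound 3 (beyond the scatter) and would lie beyond the scatter. The estimate for compound 3 is 3.9 with 3.2 to 4.6 as the expected range.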

Compound 3, distribution coefficient: 3.6
The estimate for compound 3 lay 0.30 log units above the measured number; the measured number falls inside the stated range.
By their numbers in this assay, from the lowest: compound 3; then compound 2; then compound 1.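

Going by these compounds alone, with compound 3, a single change at this position can be read for the first time: 1-hydroxy-1-methylethyl in place of methyl on a saturated chain carbon bound to an oxygen on an aromatic ring gives, in this assay, a number 1.40 log units lower from compound 1 to compound 3 (beyond the scatter). The entering group has more heavy atoms than methyl and carries a hydrogen-bond donor and acceptor, yet the number still falls. Nothing at hand explains the size of this step.

From the compounds shown here alone, how an amine, a carboxylic acid or a longer plain carbon chain in the same place would read remains open. So does which part of 1-hydroxy-1-methylethyl accounts for the step.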